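The compounds below may be only part of what the source reports. "The series", "measured", "known", "first", "only" and "open" are said of these compounds alone.

Compound 1 `Nc1c(C(=O)N/N=C/c2ccccc2)oc2nc(-c3cccs3)cc(C(F)(F)F)c12`: 9900 nM
Compound 2 `Cc1ccc(/C=N/NC(=O)c2oc3nc(-c4ccccc4)cc(C(F)(F)F)c3c2N)cc1`: 8900 nM
Compound 3 `Nc1c(C(=O)N/N=C/c2ccc(Br)cc2)oc2nc(-c3ccccc3)cc(C(F)(F)F)c12`: 19900 nM

In a functional assay on HepG2 cells (Homo sapiens) for antiproliferative activity, read by MTT assay (on this read-out lower numbers stand for stronger inhibition and higher numbers for weaker inhibition), compound 1 gives 9900 nM, a number close to that of compound 2 at 8900 nM; compound 3, at 19900 nM, differs from compound 1 by no more than the usual scatter. Compound 4 `Nc1c(C(=O)N/N=C/c2ccc(Cl)cc2)oc2nc(-c3cccs3)cc(C(F)(F)F)c12` is the unmeasured partner of compound 1, and the change is chloro in place of hydrogen on an aromatic carbon. Going by the values given here, one measured step bears on it: a 2.2-fold higher number from compound 2 to compound 3 (0.35 log units; beyond the scatter), which also brought a halogen onto that ring and gave a modestly weaker inhibitor. Taking that step as the guide, the expectation for compound 4 is a modestly higher number, a 1.4-fold higher number from compound 1 to compound 4 (0.15 log units; within the scatter), though a result within the scatter would not surprise. Compound 4 is therefore estimated at 14000 nM, with a likely range from 6000 nM to 32000 nM.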

Compound 4, half-maximal inhibitory concentration: 8100 nM
For compound 4 the middle estimate is 1.7-fold (0.24 log units) above the measured one; low and high end bracket the measured number.
By their numbers in this assay, from the lowest: compounds 4, 2, 1 and 3 (each within the scatter of the next, the first and the last beyond it).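

In this assay adding the chloro group gives a 1.2-fold lower number from compound 1 to compound 4 (0.09 log units; within the scatter) and so, at this place on the ring, para to a large group, a halogen leaves the number within the scatter of compound 1. The earlier step of a 2.2-fold higher number from compound 2 to compound 3 (0.35 log units; beyond the scatter) replaced methyl rather than hydrogen on a different core, so a halogen at this place does not by itself go with weaker inhibition. Nothing measured here explains either result.

The compounds shown leave open whether an amine or a methoxy group at this place would move the number beyond the scatter. They also leave open whether bromo would match chloro on the core of compound 1.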